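Series notes: a fluoro substitution on compound 2

The source may report more compounds than this note shows. Statements on the series, on what has been measured and on what is new or still open speak of the compounds shown alone.

Compound 1 `CCOc1cc(C(C)(C)C)ccc1C/N=C(\S)NCc1ccc(NS(C)(=O)=O)cc1`: compound 1 gives 1100 nM in a functional assay for inhibition of Vanilloid receptor (Rattus norvegicus); on this read-out higher numbers stand for weaker inhibition and lower numbers for stronger inhibition
Compound 2 `CC(C)(C)COc1cc(C(C)(C)C)ccc1C/N=C(\S)NCc1ccc(NS(C)(=O)=O)cc1`: compound 2 gives 60 nM in this assay
Compound 3 `CC(C)(C)C(=O)OCc1cc(C(C)(C)C)ccc1C/N=C(\S)NCc1ccc(NS(C)(=O)=O)cc1`: compound 3 gives 70 nM in this assay

Compound 2 has the lowest of the three numbers. Its nearest neighbour is compound 3, with a 1.2-fold higher number from compound 2 to compound 3 (0.07 log units; within the scatter), so the two cannot be ordered. Its furthest is compound 1, with an 18-fold lower number from compound 1 to compound 2 (1.26 log units; beyond the scatter); the related change gives a 16-fold lower number from compound 1 to compound 3 (1.20 log units; beyond the scatter). Both large steps come from the group on the aromatic carbon of the oxygen-bearing ring.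

Compound 4 `CC(C)(C)COc1cc(C(C)(C)C)ccc1C/N=C(\S)NCc1ccc(NS(C)(=O)=O)c(F)c1` differs from compound 2 only on the other ring: fluoro in place of hydrogen on an aromatic carbon. Within the data shown here, none of the measured steps touches this ring or a fluoro group, so nothing measured bears on the change. With no evidence either way, the expected step is no change at the digits printed from compound 2 to compound 4 (within the scatter), that is, none beyond the scatter, and compound 4 is estimated at 60 nM in this assay, within a range of 20 nM to 180 nM.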

Compound 4, half-maximal inhibitory concentration: 66 nM
Compound 4: the middle estimate sits 1.1-fold (0.04 log units) below what was measured, and the stated range covers the measured number.
By their numbers in this assay, from the lowest: compounds 2, 4 and 3 (each within the scatter of the next); then compound 1.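

Notes on the fluoro position: in this assay, fluoro in place of hydrogen, ortho to a methanesulfonamido group, gives a 1.1-fold higher number from compound 2 to compound 4 (0.04 log units; within the scatter), so the two compounds cannot be ordered. This is the only step shown on the aromatic ring carrying the methanesulfonamido group. Unlike the change on the other ring, which gives an 18-fold lower number from compound 1 to compound 2 (1.26 log units; beyond the scatter), this single substitution moves the number by no more than the scatter, and no supporting data are available to interpret that result.

Going by these compounds, whether this position would accept a chloro, methoxy or amino group in place of fluoro remains open. On these data alone, the fluoro step is also read only on the neopentyloxy compound, so its outcome on the ethoxy compound 1 or the ester compound 3 is unknown.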